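Swapping a Saturated Ring for a Pyridine in Hydroxamate Inhibitors

This account rests on a few compounds, and the source may have more. Where it says the series, first, only, none or still open, it means among the compounds named here.

Compound 2 `COc1cc2nc(-c3ccc(C)o3)cc(NCC3CCC(C(=O)NO)CC3)c2cc1OC` was tested in an assay on isolated protein for inhibition of protein deacetylase HDAC6 (Homo sapiens), read by fluorescence, with a stated time of 30 min (on this read-out lower numbers stand for stronger inhibition and higher numbers for weaker inhibition), where compound 2 gives 41 nM, the upper of the two numbers shown. Its neighbour compound 1 `COc1cc2nc(-c3ccc(C)o3)cc(NCc3ccc(C(=O)NO)cc3)c2cc1OC` gives 22 nM in this assay, and the step of a 1.9-fold higher number from compound 1 to compound 2 (0.27 log units; within the scatter) lies within the scatter. Compound 3 `COc1cc2nc(-c3ccc(C)o3)cc(NCc3ccc(C(=O)NO)cn3)c2cc1OC` is not yet measured; it differs from compound 2 in 5-(hydroxycarbamoyl)pyridin-2-yl in place of 4-(hydroxycarbamoyl)cyclohexyl on a saturated chain carbon bound to a nitrogen on an aromatic ring. Within the data shown here, the one step that bears on this change swapped an aromatic ring for a saturated one without moving beyond the scatter, so compound 3, returning to an aromatic ring, is expected to show no step beyond the scatter, a 1.5-fold lower number from compound 2 to compound 3 (0.17 log units; within the scatter). Compound 3 is therefore estimated at 28 nM, within 9 nM to 90 nM.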

Compound 3, half-maximal inhibitory concentration: 204 nM
For compound 3 the middle estimate is 7.3-fold (0.86 log units) below the measured one, and the stated range ends below it.
By their numbers in this assay, from the lowest: compounds 1 and 2 (each within the scatter of the next); then compound 3.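

In this assay, the switch to 5-(hydroxycarbamoyl)pyridin-2-yl brings a 5.0-fold higher number from compound 2 to compound 3 (0.70 log units; beyond the scatter) and a 9.3-fold higher number from compound 1 to compound 3 (0.97 log units; beyond the scatter) at this position. Being an aromatic ring is therefore not enough, since 4-(hydroxycarbamoyl)phenyl and 5-(hydroxycarbamoyl)pyridin-2-yl are both aromatic, yet only the carbon-only ring stays within the scatter of 4-(hydroxycarbamoyl)cyclohexyl. No measurement here explains why the ring with a hetero atom gives the weaker result. Still open, on these data alone, is how other pyridinyl isomers, a pyrimidine ring or a longer chain in front of the ring would behave at this position.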